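A few compounds are considered here, and "the series" means these few. Any claim that something is new, unique, unknown or untested is made for them only; others in the source may bear on it.

In an ADME assay on MRC5 cells (Homo sapiens) for cytotoxicity, read by fluorescence and resazurin assay, with a stated time of 3 days (on this read-out higher numbers stand for weaker inhibition and lower numbers for stronger inhibition), compound 1 `Cc1cn(C2CCN(Cc3cncc(Oc4cccc(Cl)c4)c3)CC2)c(=O)[nH]c1=O` gives > 64000 nM, which is a limit of the assay and not a number. Compound 2 `Cc1cn(C2CCN(Cc3cncc(Oc4cc(Cl)cc(Cl)c4)c3)CC2)c(=O)[nH]c1=O` gives > 64000 nM, again a limit and not a number. Compound 2 therefore stands at the limit of > 64000 nM in this assay, at which 2 of the 2 values shown sit, so it has no exact value to start from.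

Compound 3 `Cc1cn(C2CCN(Cc3cncc(Oc4cccc(OC(F)(F)F)c4)c3)CC2)c(=O)[nH]c1=O` keeps the shared core and changes one group: 3-(trifluoromethoxy)phenyl in place of 3,5-dichlorophenyl on an oxygen on an aromatic ring. In words, 3-(trifluoromethoxy)phenyl comes in place of 3,5-dichlorophenyl on an oxygen on an aromatic ring.

Among the compounds with values here, only one measured step bears on this change: a step that the two limits leave unreadable from compound 1 to compound 2, where chloro takes the place of hydrogen on an aromatic carbon. With a limit at both of its ends, that step offers no size to carry over, so the expectation is a cautious one. Compound 3 is expected to show no step beyond the scatter in this assay, on the strength of the limit of > 64000 nM in this assay, at which 2 of the 2 values shown sit. The estimated step is a number no higher from compound 2 to compound 3 (the limit leaves the size open). For compound 3 the expected value is 64000 nM, with an estimated range from 20000 nM to 64000 nM, and the assay may well report only a limit again.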

Compound 3, half-maximal inhibitory concentration: > 64000 nM
Compound 3: no number, only a limit; the forecaster's own chance of this, stated with the estimate: 75%; the middle value sits exactly at the limit.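

No step in size can be read among compound 1, compound 2 and compound 3, because each of them gives only a limit of the assay and not a number: the limit of > 64000 nM in this assay, at which 3 of the 3 values shown sit.

The compounds shown leave open what concentration of each would reach half-maximal inhibition in this assay, and whether swapping the group on the oxygen changes that concentration at all.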